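Trimming the Side Chain on the Amide Nitrogen of Compound 2

A few compounds are considered here, and "the series" means these few. Any claim that something is new, unique, unknown or untested is made for them only; others in the source may bear on it.

Compound 2 `CC(C)(C)OC(=O)CN1C(=O)C2(C(C#N)=C(N)Oc3cc4oc(-c5ccccc5)cc(=O)c4c(O)c32)c2ccccc21` was tested in a functional assay on NCI-H1299 cells (Homo sapiens) for antiproliferative activity, read by MTT assay, with a stated time of 48 h; on this read-out lower numbers stand for stronger inhibition and higher numbers for weaker inhibition. In this assay compound 2 gives > 50000 nM, which is a limit of the assay rather than a measured number. Its neighbour compound 1 `CN1C(=O)C2(C(C#N)=C(N)Oc3cc4oc(-c5ccccc5)cc(=O)c4c(O)c32)c2ccccc21` carries hydrogen instead of tert-butoxycarbonyl on a saturated chain carbon bound to an amide-type nitrogen in a ring. In this assay compound 1 gives > 50000 nM, again only a limit. The step that the two limits leave unreadable from compound 1 to compound 2 therefore cannot be read, and the limit of > 50000 nM in this assay, at which 2 of the 2 values shown sit, shows that no measured number exists in this small set. Compound 3 `N#CC1=C(N)Oc2cc3oc(-c4ccccc4)cc(=O)c3c(O)c2C12C(=O)Nc1ccccc12` goes one step further: hydrogen in place of (tert-butoxycarbonyl)methyl on an amide-type nitrogen in a ring. Among the measured compounds shown here, because the limit of > 50000 nM in this assay, at which 2 of the 2 values shown sit, places both known compounds at the limit, no measured step bears on this change, and the expectation is that compound 3 also reports a limit, with a step that the limit leaves unreadable from compound 2 to compound 3 that cannot be told apart from no change. Compound 3 is therefore estimated at 60000 nM, with a plausible range from 20000 nM to 200000 nM.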

Compound 3, half-maximal inhibitory concentration: > 50000 nM
Compound 3 gave a limit, no number; the forecaster's own chance of this, stated with the estimate: 75%; the middle value does not contradict the limit.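

No step among compound 1, compound 2 and compound 3 can be read in this assay, where each result is a limit and not a number: the limit of > 50000 nM in this assay, at which 3 of the 3 values shown sit.

The compounds shown leave open whether any group on the amide-type nitrogen in a ring changes the antiproliferative activity of the shared core.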